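A few compounds are considered here, and "the series" means these few. Any claim that something is new, unique, unknown or untested is made for them only; others in the source may bear on it.

Compound 1, with the structure `Nc1nc(Nc2ccc(F)cc2)sc1C(=O)c1ccccc1`, sets the starting point of this series. In a functional assay on FM3A cells (Mus musculus) for antiproliferative activity, read by cell counting, with a stated time of 2 days (a lower number here means a stronger inhibitor, a higher number a weaker inhibitor), compound 1 gives only a limit, > 10000 nM, and that is the situation described by the limit of > 10000 nM in this assay, at which 1 of the 2 values shown sits. Among the measured compounds shown here, compound 2, with the structure `COc1ccc(Nc2nc(N)c(C(=O)c3ccccc3)s2)cc1`, differs from compound 1 by methoxy in place of fluoro on an aromatic carbon; in this assay compound 2 gives 730 nM, and the step of an at least 13-fold lower number from compound 1 to compound 2 (1.13 log units; beyond the scatter) is the single measured step in the set. Compound 2 therefore holds the only true number shown, the remaining value being a limit.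

Compound 3, with the structure `COc1ccc(Nc2nc(N)c(C(=O)c3ccc(Cl)cc3)s2)cc1`, carries the change (chloro in place of hydrogen on an aromatic carbon), turning the phenyl into a 4-chlorophenyl. For the measured compounds named here, the one measured step concerns a different ring and a different pair of groups, so it says nothing direct about chloro in place of hydrogen on this aromatic carbon. Going by the values given here, with no step bearing on this change, a shift beyond the scatter in this assay is not expected in either direction. Compound 3 is estimated at 600 nM, within 200 nM to 2000 nM, an expected step of a 1.2-fold lower number from compound 2 to compound 3 (0.09 log units; within the scatter).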

Compound 3, half-maximal inhibitory concentration: 59 nM
Compound 3: the middle estimate sits 10-fold (1.01 log units) above what was measured; measured number below the stated range.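

In this assay, among the compounds shown here, the change from phenyl to 4-chlorophenyl gives a 12-fold lower number from compound 2 to compound 3 (1.09 log units; beyond the scatter), which is the first measured step at this place in the shared core. For the compounds shown here, the only earlier step, methoxy in place of fluoro, lay on the other ring, so compound 3 shows that a second place also moves the number beyond the scatter, and that a single chlorine atom with no hydrogen-bond donors or acceptors is enough to do so. Nothing given here accounts for the size of this step.

Only hydrogen and chloro are shown on this carbon, so it stays open how a methyl, a trifluoromethyl, an amine or a carboxylic acid there would read in this assay, and whether chloro on another carbon of this ring would give a similar number. The chloro is also seen only alongside the methoxy on the other ring, which leaves open whether the same step would appear with the fluoro of compound 1 in its place.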